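Swapping 4-methylphenyl for pyridin-2-yl on compound 2

The compounds below may be only part of what the source reports. "The series", "measured", "known", "first", "only" and "open" are said of these compounds alone.

Compound 2 `Cc1ccc(-c2cn(C/C=C3\OC(=O)C(OCc4ccccc4)=C3OCc3ccccc3)nn2)cc1` is the starting point. In a functional assay on HCT-116 cells (Homo sapiens) for antiproliferative activity, read by MTT assay, with a stated time of 24 h (on this read-out lower numbers stand for stronger inhibition and higher numbers for weaker inhibition), compound 2 gave no number but only the limit of the assay, > 100000 nM. Compound 1 `CC(C)(C)c1ccc(-c2cn(C/C=C3\OC(=O)C(OCc4ccccc4)=C3OCc3ccccc3)nn2)cc1` shares the same core and differs only in a tert-butyl group. In this assay compound 1 also gave only the limit, > 100000 nM. The step that the two limits leave unreadable from compound 1 to compound 2 therefore cannot be sized, since both values sit at the limit of > 100000 nM in this assay, at which 2 of the 3 values shown sit. Compound 3 `COC1=C(OC)C(O)(CCn2cc(-c3ccccc3)nn2)NC1=O` is built on a different core; in this assay compound 3 gave 46300 nM, a number rather than a limit, yet still a weak one.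

Compound 4 `O=C1O/C(=C\Cn2cc(-c3ccccn3)nn2)C(OCc2ccccc2)=C1OCc1ccccc1` differs from compound 2 in one place: pyridin-2-yl in place of 4-methylphenyl on an aromatic carbon. No measured pair among these compounds follows a change of this kind, and the one measured step, a step that the two limits leave unreadable from compound 1 to compound 2, concerns a different group and cannot be read. The two compounds on this core, compound 1 and compound 2, both rest at the limit, so no movement beyond the scatter can be foreseen from the data.

Compound 4 is therefore expected to come out near 120000 nM, most likely between 30000 nM and 500000 nM. The expected step is thus a step that the limit leaves unreadable from compound 2 to compound 4, which is to say essentially no change from the limit at which compound 2 stands.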

Compound 4, half-maximal inhibitory concentration: > 100000 nM
Compound 4: only a limit was reported (the forecaster's own chance of this, stated with the estimate: 70%); the middle value does not contradict the limit.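

Compound 4 gives > 100000 nM as a limit and not a number. Compound 1 and compound 2 also have only limits, so no step among these three compounds can be read. The compounds shown leave open whether pyridin-2-yl or 4-methylphenyl on the shared core gives any real difference in inhibition.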